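From trifluoromethoxy to cyano on a shared core

This account rests on a few compounds, and the source may have more. Where it says the series, first, only, none or still open, it means among the compounds named here.

In an ADME assay on L6 cells (Rattus norvegicus) for cytotoxicity, read by resazurin assay, with a stated time of 72 h (a lower number here means a stronger inhibitor, a higher number a weaker inhibitor), compound 1 (`CCc1ccc(C(=O)NC(=O)c2ccccc2O)cc1`) gives 70 ug/mL and compound 2 (`O=C(NC(=O)c1ccccc1O)c1ccc(OC(F)(F)F)cc1`) gives 84 ug/mL on the same scale. Among the compounds with values here, the two numbers cannot be told apart within the usual scatter, so compound 2 stands together with the only other measured compound. Compound 3 (`N#Cc1ccc(C(=O)NC(=O)c2ccccc2O)cc1`) keeps the shared core and carries cyano in place of trifluoromethoxy on an aromatic carbon. Within the data shown here, one measured step bears on this: a 1.2-fold higher number from compound 1 to compound 2 (0.08 log units; within the scatter) came with trifluoromethoxy in place of ethyl on an aromatic carbon. Among the measured compounds shown here, that is thin evidence, since no compound with cyano has been measured yet. The expected change is a 1.1-fold lower number from compound 2 to compound 3 (0.05 log units; within the scatter) and thus no real step in either direction. For compound 3 the estimate is 75 ug/mL with an expected range from 38 ug/mL to 100 ug/mL in this assay when measured.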

Compound 3, half-maximal inhibitory concentration: 55 ug/mL
The estimate for compound 3 lay 1.4-fold (0.13 log units) above the measured number; measured number inside the range.
By their numbers in this assay, from the lowest: compounds 3, 1 and 2 (each within the scatter of the next).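

In this assay, cyano at this place, on an aromatic carbon para to a large group, gives a 1.5-fold lower number from compound 2 to compound 3 (0.18 log units; within the scatter) and, set against ethyl, gives a 1.3-fold lower number from compound 1 to compound 3 (0.10 log units; within the scatter) in the same assay. Ethyl, trifluoromethoxy and cyano therefore cannot be told apart here, even though cyano brings a triple bond and fewer heavy atoms than trifluoromethoxy, so this position has now tolerated three different groups with no real step in the number. No measurement is available that would explain this flat result.

Going by these compounds, whether an amine or a carboxylic acid at this place would move the number beyond the scatter stays open. So does whether a longer chain here would leave it as flat as these three groups have.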